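The source may hold more compounds than are shown below. What is called first, only, known or untested is meant among the compounds shown, and "the series" means these compounds.

Compound 1 `N[C@H]1CC[C@H](NC(=O)c2nc(Br)c3cccnc3c2NCc2ccc(F)cc2)CC1` and compound 2 `N[C@H]1CC[C@H](Nc2c(C(=O)NCc3ccc(F)cc3)nc(Br)c3cccnc23)CC1` share a brominated core and differ in how the 4-aminocyclohexyl and 4-fluorobenzyl groups are arranged. In a functional assay on HCT-116 cells (Homo sapiens) for cytotoxicity, read by MTT assay, with a stated time of 72 h (a higher number here means a weaker inhibitor, a lower number a stronger inhibitor), compound 1 gives 6400 nM, and compound 2 gives 7000 nM. Compound 3 `NCCCNc1c(C(=O)NCc2ccc(F)cc2)nc(Br)c2cccnc12` carries 3-aminopropyl on the nitrogen on the aromatic ring. In this assay compound 3 gives > 20000 nM, a limit rather than a number. This value is the limit of > 20000 nM in this assay, at which 1 of the 3 values shown sits. Among the measured compounds shown here, the one measured step at this position, an at least 2.8-fold higher number from compound 2 to compound 3 (0.45 log units; beyond the scatter), weakened activity. Compound 4 `O=C(NCc1ccc(F)cc1)c1nc(Br)c2cccnc2c1NCc1ccc(F)cc1` differs from compound 3 by 4-fluorophenyl in place of 2-aminoethyl on a saturated chain carbon bound to a nitrogen on an aromatic ring. For the measured compounds named here, no measured step covers this exchange, so compound 4 is expected near the limit; the estimated step is a number no higher from compound 3 to compound 4 (the limit leaves the size open), and compound 4 is estimated at 20000 nM, between 7000 nM and 60000 nM.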

Compound 4, half-maximal inhibitory concentration: > 20000 nM
Compound 4 ended at the assay's limit; the forecaster's own chance of this, stated with the estimate: 50%; the middle value sits exactly at the limit.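

In this assay, 4-fluorobenzyl in place of 4-aminocyclohexyl also costs activity, with an at least 2.8-fold higher number from compound 2 to compound 4 (0.45 log units; beyond the scatter) on the nitrogen on the aromatic ring and an at least 3.1-fold higher number from compound 1 to compound 4 (0.49 log units; beyond the scatter) on the amide-type nitrogen, so the loss is not confined to the exchange for 3-aminopropyl. Compound 4 stands at a limit rather than a number: the limit of > 20000 nM in this assay, at which 2 of the 4 values shown sit. The step between compound 3 and compound 4 cannot be read.

From the compounds shown here alone, whether a plain cyclohexyl group without its amine, or a longer aminoalkyl chain, would hold the activity of compound 2 remains open.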